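The compounds below may be only part of what the source reports. "The series", "measured", "known", "first", "only" and "open" are said of these compounds alone.

Series notes. Compound 1 `Cc1cc(-c2ccc(C=O)cc2)cn2c(CSCCc3ccccc3)cnc12` stands as the higher of the two numbers measured in an ADME assay on HEL cells (Homo sapiens) for cytotoxicity, with a stated time of 3 days; on this read-out higher numbers stand for lower toxicity in this test and lower numbers for higher toxicity in this test: compound 1 gives 100 ug/mL, while compound 2 `Cc1cc(-c2ccsc2)cn2c(CSCc3ccccc3)cnc12` gives 4 ug/mL. Compound 2 differs from compound 1 in more than one place, so the two values show only that the gap between them is beyond the scatter. Compound 3 `Cc1cc(N2CCCC2)cn2c(CSCCc3ccccc3)cnc12` carries pyrrolidin-1-yl in place of 4-formylphenyl on an aromatic carbon. Among the measured compounds shown here, no single-change step between measured compounds exists to anchor this change; a moderate step downward is expected, a 3.3-fold lower number from compound 1 to compound 3 (0.52 log units; beyond the scatter). Compound 3 is therefore estimated at 30 ug/mL, with a range from 5 ug/mL to 100 ug/mL.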

Compound 3, minimum cytotoxic concentration: 20 ug/mL
Compound 3: the middle estimate sits 1.5-fold (0.18 log units) above what was measured; low and high end bracket the measured number.
By their numbers in this assay, from the lowest: compound 2; then compound 3; then compound 1.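

Among the compounds shown here, with the rest of the molecule unchanged, pyrrolidin-1-yl in place of 4-formylphenyl on this aromatic carbon gives a 5.0-fold lower number from compound 1 to compound 3 (0.70 log units; beyond the scatter) in this assay, the first single-place reading at this position. The lower number stands for higher toxicity in this test, so the group at this position alone changes the read-out beyond the scatter. Nothing available accounts for the size or direction of this step.

As far as these compounds go, whether the formyl group or the phenyl ring carries the difference stays open. A plain phenyl or an open-chain dimethylamino group at this position would help separate the two.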